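Swapping Methyl for Chloro on an Aromatic Carbon

The source may hold more compounds than are shown below. What is called first, only, known or untested is meant among the compounds shown, and "the series" means these compounds.

Within the data shown here, in an ADME assay on HCT-116 cells (Homo sapiens) for antiproliferative activity (a higher number here means a weaker inhibitor, a lower number a stronger inhibitor), compound 2 (`COc1ccc(C(N)=O)cc1/C=C/c1ccccc1C`) gives 11000 nM, the lowest of the two numbers measured so far. Among the measured compounds shown here, the only other measured compound, compound 1 (`COc1ccc(C(N)=O)cc1/C=C/c1ccccc1F`), gives 26000 nM, so compound 2 is the stronger inhibitor of the pair by a margin beyond the scatter.

The next compound, compound 3 (`COc1ccc(C(N)=O)cc1/C=C/c1ccccc1Cl`), carries chloro in place of methyl on an aromatic carbon. For the measured compounds named here, one measured step bears on this change, the modest 2.4-fold lower number from compound 1 to compound 2 (0.37 log units; beyond the scatter), which replaced fluoro with methyl on that same carbon. Going by the values given here, no chloro compound has been measured yet, so this single step gives the only guide to the size of change that can be expected from a swap at this carbon. Since that step was modest, no large shift is expected, and any movement is expected to be towards a somewhat higher number.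

The estimated change is a 1.3-fold higher number from compound 2 to compound 3 (0.10 log units; within the scatter), which is expected to stay within the scatter. For compound 3 the expected value is 14000 nM, with an estimated range from 6500 nM to 30000 nM.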

Compound 3, half-maximal inhibitory concentration: > 50000 nM
Compound 3 was reported as a limit (the forecaster's own chance of this, stated with the estimate: 5%); at least 3.5-fold (0.55 log units) between middle value and limit.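

The change of methyl for chloro on this aromatic carbon, ortho to a large group, proves far from neutral in this assay: it gives an at least 4.5-fold higher number from compound 2 to compound 3 (0.65 log units; beyond the scatter), a larger step than the one the earlier pair had shown at this carbon. Of the three groups shown here, methyl alone gives a number clearly separated from both others, so the two halogen compounds do not match it, and chloro does not behave as a stand-in for methyl at this carbon. The comparison with fluoro is less firm, since the change gives an at least 1.9-fold higher number from compound 1 to compound 3 (0.28 log units; that floor lies within the scatter), which leaves the true gap between these two compounds undefined, and compound 3 is reported only as a limit, which sets a floor on both steps rather than their true size: the limit of > 50000 nM in this assay, at which 1 of the 3 values shown sits.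

The compounds shown leave open how an amine, a hydroxyl or a longer chain on this same carbon would read in this assay. They also leave open whether the advantage of methyl over fluoro and chloro would hold if the amide of the shared core gave way to a carboxylic acid.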